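Swapping a Butyl Chain for Cyclopentyl on Two Cores

This account rests on a few compounds, and the source may have more. Where it says the series, first, only, none or still open, it means among the compounds named here.

Compound 1 `CCCCn1cnc2c(NCc3ccc(C(=O)Nc4ccccc4N)cc3)nc(Cl)nc21` and compound 2 `Nc1ccccc1NC(=O)c1ccc(CNc2nc(Cl)nc3c2ncn3C2CCCC2)cc1` share one core. In a functional assay on HepG2 cells (Homo sapiens) for antiproliferative activity, read by CCK-8 assay, with a stated time of 72 h, tested at 8 uM (on this read-out higher numbers stand for a stronger effect at the one concentration tested and lower numbers for a weaker effect), compound 1 gives 19.6%, while compound 2 gives 74.9%. Among the measured compounds shown here, the single change between them, (cyclopentyl in place of butyl on an aromatic nitrogen), made the step of a number 55.3 percentage points higher from compound 1 to compound 2 (beyond the scatter). Compound 3 `CCCCn1cnc2c(Nc3ccccc3)nc(NCOCc3ccc(/C=C/C(=O)Nc4ccccc4N)cc3)nc21` rests on a different core; the difference between the two cores is not broken down here. In this assay compound 3 gives 59.3%. Compound 4 `Nc1ccccc1NC(=O)/C=C/c1ccc(COCNc2nc(Nc3ccccc3)c3ncn(C4CCCC4)c3n2)cc1` carries the same change on the core of compound 3, namely (cyclopentyl in place of butyl on an aromatic nitrogen), at a place described in identical words. A smaller rise is expected this time, a number 24.7 percentage points higher from compound 3 to compound 4 (beyond the scatter), because compound 3 already gives 59.3% and leaves little room upward. Compound 4 is therefore expected to reach about 84% in this assay, within a range from 65% to 97%.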

Compound 4, a percentage reported as inhibition, at one concentration (the size of the read-out at that concentration, not a potency): 18.8%
Beside the measured number, compound 4's estimate is 65.2 percentage points above it; the measured number lies below the stated range.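

Placed on the core of compound 3, cyclopentyl in place of butyl gave a number 40.5 percentage points lower from compound 3 to compound 4 (beyond the scatter) in this assay. The same swap therefore did not carry over from one core to the other, and its direction reversed: the same change on two cores in this assay, a number 55.3 percentage points higher (beyond the scatter) from compound 1 to compound 2 and a number 40.5 percentage points lower (beyond the scatter) from compound 3 to compound 4, 95.8 percentage points apart, beyond the scatter of two such steps. This shows that the outcome of the swap depends on the core in this series, but two pairs do not show which difference between the cores is responsible or what a further core would do.

The compounds shown leave open how other groups on this aromatic nitrogen, such as a propyl chain, a cyclohexyl ring or a benzyl group, would behave on each core. They also leave open whether the reversal would hold at other concentrations.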